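The compounds below may be only part of what the source reports. "The series", "measured", "known", "first", "only" and "open" are said of these compounds alone.

Measured so far in a functional assay on CHO cells with adenosine receptor A1 (Homo sapiens) as the target, read by cAMP accumulation and immunoassay, with a stated time of 6 min, tested at 0.01 uM; on this read-out higher numbers stand for a weaker effect at the one concentration tested and lower numbers for a stronger effect:

Compound 1 `Nc1scc(CN2CCN(c3ccc(Cl)cc3Cl)CC2)c1C(=O)c1ccc(Cl)cc1` gives 2%.
Compound 2 `Nc1scc(CN2CCN(c3cccc4ccccc34)CC2)c1C(=O)c1ccc(Cl)cc1` gives 8.7%.
Compound 3 `Nc1scc(CN2CCN(c3ccc(F)c(Cl)c3)CC2)c1C(=O)c1ccc(Cl)cc1` gives 4.2%.

Compound 3 stands second highest of these three numbers; the step of a number 2.2 percentage points higher from compound 1 to compound 3 (within the scatter) and the step of a number 4.5 percentage points lower from compound 2 to compound 3 (within the scatter) are both within the scatter, as is a number 6.7 percentage points higher from compound 1 to compound 2 (within the scatter). Compound 4 `Nc1scc(CN2CCN(CCCc3ccc(Cl)cc3)CC2)c1C(=O)c1ccc(Cl)cc1` differs from compound 3 by 3-(4-chlorophenyl)propyl in place of 3-chloro-4-fluorophenyl on an amine nitrogen in a ring. The three measured steps all swap one aromatic group for another on the same ring nitrogen and none moved the read-out beyond the scatter. Going by the values given here, no measured step covers a 3-(4-chlorophenyl)propyl group, so the bearing of those steps is only indirect. On that basis no step beyond the scatter is expected, a number 2.8 percentage points higher from compound 3 to compound 4 (within the scatter). For compound 4 the estimated value is 7%, with a range from -5% to 30%.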

Compound 4, a percentage reported as activity, at one concentration (the size of the read-out at that concentration, not a potency): 0%
The estimate for compound 4 lay 7 percentage points above the measured number; measured number inside the range.
By their numbers in this assay, from the lowest: compounds 4, 1, 3 and 2 (each within the scatter of the next).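

Putting 3-(4-chlorophenyl)propyl on the amine nitrogen in a ring gives a number 4.2 percentage points lower from compound 3 to compound 4 (within the scatter), a number 2 percentage points lower from compound 1 to compound 4 (within the scatter) and a number 8.7 percentage points lower from compound 2 to compound 4 (within the scatter) in this assay. Thus, among these compounds, the insensitivity of this position extends from aromatic groups on the nitrogen to the first group shown with a propyl chain. No evidence given here accounts for this result. Going by these compounds, it remains open whether a shorter or longer chain, or an amine or carboxylic acid at the end of the propyl chain, would give a step beyond the scatter. On these data alone, the read-out gives only the size of the effect at the one concentration tested, and it is open whether the effect would be stronger or weaker at any other concentration.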